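The source may report more compounds than this note shows. Statements on the series, on what has been measured and on what is new or still open speak of the compounds shown alone.

Compound 1: `COc1ccc(CCCCCCCCOc2ccc(C[S+]([O-])c3cccc(C(=O)O)c3)nc2/C=C/C(=O)O)cc1` – 3900 nM
Compound 2: `COc1ccc(CCCCCCCCOc2ccc(CSCc3cccc(C(=O)O)c3)nc2CCC(=O)O)cc1` – 240 nM

Of the compounds shown here, two have been measured in a functional assay on the whole organism with Homo sapiens as the target, read by calcium flux; on this read-out lower numbers stand for stronger inhibition and higher numbers for weaker inhibition. Among the compounds with values here, compound 1 gives 3900 nM, the higher of the two numbers, and compound 2 gives 240 nM, a far lower number that lies beyond the scatter of this assay; no single-point step connects these two structures, so their values are simply set side by side. Compound 3, `COc1ccc(CCCCCCCCOc2ccc(CSCc3ccc(C(=O)O)cc3)nc2/C=C/C(=O)O)cc1`, has not yet been measured. It differs from compound 1 by a group of 11 heavy atoms (8 carbon, 2 oxygen, 1 sulfur; one six-membered aromatic ring of carbon only) in place of a group of 11 heavy atoms (7 carbon, 3 oxygen, 1 sulfur; one six-membered aromatic ring of carbon only), on a saturated chain carbon bound to an aromatic carbon — a group of 11 heavy atoms (8 carbon, 2 oxygen, 1 sulfur; one six-membered aromatic ring of carbon only) in place of a group of 11 heavy atoms (7 carbon, 3 oxygen, 1 sulfur; one six-membered aromatic ring of carbon only), on a saturated chain carbon bound to an aromatic carbon. Since compound 2, which also carries a sulfanyl linkage, gives 240 nM, a step toward lower numbers is expected, a 6.5-fold lower number from compound 1 to compound 3 (0.81 log units; beyond the scatter) being the estimated size. Compound 3 is therefore expected at 600 nM, within a range of 150 nM to 2500 nM.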

Compound 3, half-maximal inhibitory concentration: 175 nM
Compound 3: middle estimate off by 3.4-fold (0.54 log units), on the high side; the range from low to high includes it.
By their numbers in this assay, from the lowest: compounds 3 and 2 (each within the scatter of the next); then compound 1.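

Read in this assay the exchange on a saturated chain carbon bound to an aromatic carbon gives a 22-fold lower number from compound 1 to compound 3 (1.35 log units; beyond the scatter) and is the first comparison here in which two compounds differ in one place only. It shows that this place strongly affects the read-out, since the (4-carboxybenzyl)sulfanyl group goes with much stronger inhibition than the group it replaces while the rest of compound 1 stays the same. The group changes as a whole, so the step cannot be assigned to any one part of it, and no measurement bears on the cause of this result.

On these data alone, whether the step survives when the carboxylic acid of the entering group gives way to a tetrazole or an amide remains open. So does the effect of a longer chain between the sulfur and the aromatic ring.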